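Replacing 4-chlorophenyl with phenyl in an antiproliferative series

This account rests on a few compounds, and the source may have more. Where it says the series, first, only, none or still open, it means among the compounds named here.

Compound 1 `COc1ccc(-c2nc(SCC(=O)c3sc(-c4ccccc4)nc3C)nc(N)c2C#N)cc1` (14000 nM)
Compound 2 `Cc1nc(-c2ccccc2)sc1C(=O)CSc1nc(N)c(C#N)c(-c2ccc(Cl)cc2)n1` (10800 nM)

Among the measured compounds shown here, in a functional assay on U-87MG ATCC cells for antiproliferative activity against U-87 MG (Homo sapiens), read by MTT assay, with a stated time of 48 h (a higher number here means a weaker inhibitor, a lower number a stronger inhibitor), compound 2 stands level with compound 1, its only measured neighbour, since the two values lie within the scatter of each other. Compound 3 `Cc1nc(-c2ccccc2)sc1C(=O)CSc1nc(N)c(C#N)c(-c2ccccc2)n1` differs from compound 2 by a single change (hydrogen in place of chloro on an aromatic carbon), hydrogen in place of chloro on an aromatic carbon. For the measured compounds named here, the one measured step that bears on it put chloro in place of methoxy on that same carbon (a 1.3-fold lower number from compound 1 to compound 2 (0.11 log units; within the scatter)) and stayed within the scatter. Going by the values given here, one step is a thin basis, and no compound with hydrogen there has been measured yet. No step beyond the scatter is therefore expected in this assay for this change. The expected step is small (a 1.2-fold higher number from compound 2 to compound 3 (0.08 log units; within the scatter)). Compound 3 is estimated at 13000 nM (range 6500 nM to 26000 nM).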

Compound 3, half-maximal inhibitory concentration: 29000 nM
Compound 3: middle estimate off by 2.2-fold (0.35 log units), on the low side; measured number above the stated range.
By their numbers in this assay, from the lowest: compounds 2 and 1 (each within the scatter of the next); then compound 3.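

In this assay, hydrogen on this aromatic carbon proves not to be interchangeable with the two substituents, as the unsubstituted phenyl gives a higher number than either the 4-chlorophenyl (a 2.7-fold higher number from compound 2 to compound 3 (0.43 log units; beyond the scatter)) or the methoxy-bearing ring (a 2.1-fold higher number from compound 1 to compound 3 (0.32 log units; beyond the scatter)). The earlier step compared only chloro with methoxy, and their values within the scatter could not show that having either group at this carbon separates a compound from its hydrogen counterpart. Nothing available explains this difference.

As far as these compounds go, it remains open whether the lower number extends to other groups at this carbon, such as fluoro, methyl or an amine. Also open, from the compounds shown here alone, is whether a carboxylic acid or a longer alkoxy chain there would stay level with chloro and methoxy or fall with hydrogen.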